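Furan in place of thiophene: expectation for compound 4

The source may hold more compounds than are shown below. What is called first, only, known or untested is meant among the compounds shown, and "the series" means these compounds.

Three compounds of the shared core have been run in a functional assay on K562 cells (Homo sapiens), read by MTT assay, with a stated time of 72 h; a lower number here means a stronger inhibitor, a higher number a weaker inhibitor. In this assay compound 1 `Cc1nc(N)c2c(-c3cccs3)cn([C@@H]3O[C@H](CO)[C@@H](O)[C@H]3O)c2n1` gives only a limit, > 20000 nM. Compound 2 `COc1nc(N)nc2c1c(-c1cccs1)cn2[C@@H]1O[C@H](CO)[C@@H](O)[C@H]1O` also returns only a limit in this assay, > 20000 nM. Compound 3 `Nc1nc(N)c2c(-c3cccs3)cn([C@@H]3O[C@H](CO)[C@@H](O)[C@H]3O)c2n1` likewise stops at a limit in this assay, > 20000 nM. The two measured steps into compound 3, a step that the two limits leave unreadable from compound 1 to compound 3 and a step that the two limits leave unreadable from compound 2 to compound 3, carry no readable size because of the limit of > 20000 nM in this assay, at which 3 of the 3 values shown sit. Compound 3 thus stands at the limit of this assay, with no number behind it.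

Compound 4 `Nc1nc(N)c2c(-c3ccco3)cn([C@@H]3O[C@H](CO)[C@@H](O)[C@H]3O)c2n1` differs from compound 3 by furan-2-yl in place of thiophen-2-yl on an aromatic carbon. For the measured compounds named here, no measured step bears on this change; the only steps in hand concern the amino group of compound 3 and were themselves unreadable. With every value in the series sitting at the limit, no step beyond the scatter is expected in this assay from compound 3 to compound 4, a number no higher from compound 3 to compound 4 (the limit leaves the size open). Compound 4 is therefore estimated to give 20000 nM in this assay, within 8000 nM to 50000 nM, and is expected most likely to be reported again only as a limit.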

Compound 4, half-maximal inhibitory concentration: > 20000 nM
Compound 4 was reported as a limit (the forecaster's own chance of this, stated with the estimate: 85%); the middle value lies on the limit itself.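

Compound 3 and compound 4 both stop at a limit in this assay, so no size can be read for furan-2-yl in place of thiophen-2-yl: the limit of > 20000 nM in this assay, at which 4 of the 4 values shown sit.

The compounds shown leave open what number lies behind any of these limits, and whether the two rings differ at all in this assay.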